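This account rests on a few compounds, and the source may have more. Where it says the series, first, only, none or still open, it means among the compounds named here.

Measured so far in a functional assay on DU-145 cells (Homo sapiens) for antiproliferative activity, read by WST assay, with a stated time of 3 days; a higher number here means a weaker inhibitor, a lower number a stronger inhibitor:
- compound 1 `CCCCOc1c(-c2cc(OC)c(OC)c(OC)c2)oc2ccccc2c1=O`: > 50000 nM (a limit of the assay)
- compound 2 `CCCCCCOc1c(-c2cc(OC)c(OC)c(OC)c2)oc2ccccc2c1=O`: > 50000 nM (a limit of the assay)
- compound 3 `CCCN(CCC)CCCCCOc1c(-c2cc(OC)c(OC)c(OC)c2)oc2ccccc2c1=O`: 24200 nM

Compound 3 is the only one of the three with an actual number, 24200 nM. The other two values stand at one shared limit, (the limit of > 50000 nM in this assay, at which 2 of the 3 values shown sit), so compound 3 can only be placed against that limit.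

The next compound to be measured is compound 4 `CCCCCN(CCCCC)CCCOc1c(-c2cc(OC)c(OC)c(OC)c2)oc2ccccc2c1=O`. It carries dipentylamino in place of 2-(dipropylamino)ethyl on a saturated chain carbon, three bonds along the chain from an oxygen on an aromatic ring.

Within the data shown here, two measured steps bear on this change, both of them toward the amine-bearing compound 3: an at least 2.0-fold lower number from compound 1 to compound 3 (0.31 log units; beyond the scatter) and an at least 2.0-fold lower number from compound 2 to compound 3 (0.31 log units; beyond the scatter). Both are minimum sizes set by the limit. The third step, a step that the two limits leave unreadable from compound 1 to compound 2, has no amine in it and gives no size. Among the measured compounds shown here, no measured step alters the groups on the nitrogen or the length of the chain leading to it, so the guidance is weak.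

Compound 4 keeps an amine, so a measurable number is expected, and a modest fall is tentatively expected. The expected step in this assay is a 2.7-fold lower number from compound 3 to compound 4 (0.43 log units; beyond the scatter). For compound 4 the estimated value is 9000 nM, with an expected range of 2500 nM to 32000 nM.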

Compound 4, half-maximal inhibitory concentration: 12300 nM
Compound 4: middle estimate off by 1.4-fold (0.14 log units), on the low side; measured number inside the range.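

In this assay, exchanging 2-(dipropylamino)ethyl for dipentylamino, on a saturated chain carbon three bonds along the chain from an oxygen on an aromatic ring, gives a 2.0-fold lower number from compound 3 to compound 4 (0.29 log units; within the scatter) and so leaves no readable difference, although the chain and the groups on the nitrogen both change. Compound 4 is a second amine with a measured number, and among these four compounds both amines give numbers while both compounds without an amine stay at a limit, with no compound going against this. Against the compounds without an amine, dipentylamino gives an at least 4.0-fold lower number from compound 2 to compound 4 (0.60 log units; beyond the scatter) and an at least 4.0-fold lower number from compound 1 to compound 4 (0.60 log units; beyond the scatter) and both sizes are minimums because those two values are limits: the limit of > 50000 nM in this assay, at which 2 of the 4 values shown sit.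

Chain length and the groups on the nitrogen change together between compound 3 and compound 4, so the part played by each stays unresolved; dipropylamino on the shorter chain or dipentylamino on the longer chain would separate them. Also open, as far as these compounds go, is how the series reads with a cyclic amine such as piperidine or morpholine, or with a primary amine, in place of these dialkylamines.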